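Benzamide in Place of Propanamide on a Shared Core

A few compounds are considered here, and "the series" means these few. Any claim that something is new, unique, unknown or untested is made for them only; others in the source may bear on it.

Three compounds that share a central aryl thioether motif bearing a methylpiperazine group have been tested in a functional assay on SK-BR-3 cells (Homo sapiens) for cytotoxicity, read by resazurin assay, with a stated time of 72 h; a higher number here means a weaker inhibitor of growth, a lower number a stronger inhibitor of growth. Compound 1 `Cc1nc(N2CCN(C)CC2)nc(C)c1Sc1nccc(NC(=O)c2ccco2)n1` gives 30 uM. Compound 3 `COc1nc(N2CCN(C)CC2)nc(OC)c1Sc1nccc(NC(=O)C2CC2)n1` gives 15 uM. Compound 2 `CCC(=O)Nc1cccc(Sc2c(OC)nc(N3CCN(C)CC3)nc2OC)c1` gives 55 uM, the highest of the three numbers; its gap to compound 1 lies within the scatter, while its gap to compound 3 lies beyond it.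

The next compound, compound 4 `COc1nc(N2CCN(C)CC2)nc(OC)c1Sc1cccc(NC(=O)c2ccccc2)c1`, keeps everything in compound 2 except the amide end. The change is phenyl in place of ethyl on a carbonyl carbon, so that the propanoylamino group becomes a benzamido group.

Within the data shown here, no measured pair shows this exact change, so the direction is uncertain. Compound 1, which also carries an aromatic ring on the carbonyl carbon, gives 30 uM, and compound 3 gives 15 uM; both are lower numbers than compound 2. A modest move toward stronger growth inhibition is therefore expected, and the step of a 1.6-fold lower number from compound 2 to compound 4 (0.20 log units; within the scatter) is estimated to stay near the edge of the scatter. Compound 4 is expected to give about 35 uM, between 12 uM and 100 uM.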

Compound 4, concentration for growth inhibition (reported as GI): 8 uM
Compound 4: the middle estimate sits 4.4-fold (0.64 log units) above what was measured, outside the stated range (below it).
By their numbers in this assay, from the lowest: compounds 4, 3, 1 and 2 (each within the scatter of the next, the first and the last beyond it).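

Phenyl in place of ethyl on a carbonyl carbon gives a 6.9-fold lower number from compound 2 to compound 4 (0.84 log units; beyond the scatter) in this assay. Among these compounds, this is the first step in the set that changes one place alone, and it shows that the group on this carbonyl carbon can move the growth-inhibition number beyond the scatter. The change adds carbon atoms and an aromatic ring but no hydrogen-bond donor, hydrogen-bond acceptor or net charge, and no measurement shown explains the drop.

This single step cannot separate the effect of the aromatic ring from that of a larger carbon group, a question that a cyclohexyl ring or a longer chain such as butyl on the same carbonyl carbon could address. From the compounds shown here alone, how a chlorine atom or an amine on the new phenyl ring would shift the number also remains open.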